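Chloro to Fluoro on the Shared Core: Compound 3

The compounds below may be only part of what the source reports. "The series", "measured", "known", "first", "only" and "open" are said of these compounds alone.

Compound 2 `O=C(NOCc1ccccc1Cl)c1cn(-c2ccccc2)nc1-c1ccc(Cl)cc1` is one of two compounds with a number in a functional assay on A549 cells (Homo sapiens) for antiproliferative activity, read by MTT assay, with a stated time of 48 h, in the presence of a further agent that is not named here (on this read-out lower numbers stand for stronger inhibition of growth and higher numbers for weaker inhibition of growth), where compound 2 gives 15500 nM. Going by the values given here, that is the higher of the two numbers; compound 1 `Cc1ccc(-c2nn(-c3ccccc3)cc2C(=O)NOCc2ccccc2Cl)cc1` gives 380 nM in this assay, and the only step known between them is a 41-fold higher number from compound 1 to compound 2 (1.61 log units; beyond the scatter). Compound 3 `O=C(NOCc1ccccc1Cl)c1cn(-c2ccccc2)nc1-c1ccc(F)cc1` has not yet been measured; it differs from compound 2 by fluoro in place of chloro on an aromatic carbon. This change is not the same as the one measured, but it touches the same group: the chloro that, when it stood in place of methyl, went with the large step from compound 1 to compound 2. Fluoro appears in neither measured compound, so whether it behaves like chloro or like methyl cannot be read from these two points; a move back toward the lower number of compound 1 is plausible but not assured. Compound 3 is therefore expected to give 3500 nM in this assay, within a range from 700 nM to 17000 nM, which would mean an estimated step of a 4.4-fold lower number from compound 2 to compound 3 (0.65 log units; beyond the scatter).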

Compound 3, concentration for 50% growth inhibition: 8330 nM
Estimate against measurement, compound 3: 2.4-fold (0.38 log units) below, and the stated range covers the measured number.
By their numbers in this assay, from the lowest: compound 1; then compounds 3 and 2 (each within the scatter of the next).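

In this assay the change from 4-chlorophenyl to 4-fluorophenyl gives a 1.9-fold lower number from compound 2 to compound 3 (0.27 log units; within the scatter) and so stays within the scatter, which means chloro and fluoro cannot be told apart at this place on the ring. Set against methyl, fluoro gives a 22-fold higher number from compound 1 to compound 3 (1.34 log units; beyond the scatter) and this large step lies beyond the scatter, so the large step seen earlier is not special to chloro: across these three compounds, both halogens stand apart from methyl, and compound 1 alone has the low number. Nothing measured here gives a reason for this gap between methyl and the two halogens.

Three groups at a single place cannot show whether methyl is unusual or whether chloro and fluoro share a drawback, and a plain hydrogen, an ethyl, a methoxy or an amine at this place could point either way. As far as these compounds go, it also remains open whether the gap between methyl and the halogens would hold if another part of the shared core were changed, such as the phenyl on the ring nitrogen or the chlorinated benzyl group.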